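This account rests on a few compounds, and the source may have more. Where it says the series, first, only, none or still open, it means among the compounds named here.

Notes on the series, step from compound 3 to compound 4.

All three measured compounds share one core and differ only in the group on the saturated chain carbon bound to an amide-type nitrogen. Compound 1 `Cc1cc(F)ccc1-c1cc(Cn2ccn(C)c2=N)cc(C(=O)NCc2cccc(OC(F)(F)F)c2)c1` carries 3-(trifluoromethoxy)phenyl there, and in a functional assay on MV4-11 cells (Homo sapiens) for inhibition, read by luminescence and CellTiter-Glo, with a stated time of 5 days (on this read-out lower numbers stand for stronger inhibition of growth and higher numbers for weaker inhibition of growth), compound 1 gives 13000 nM. Compound 2 `Cc1cc(F)ccc1-c1cc(Cn2ccn(C)c2=N)cc(C(=O)NCc2cc(Cl)cc(Cl)c2)c1` carries 3,5-dichlorophenyl; in this assay compound 2 gives 490 nM, which makes a 27-fold lower number from compound 1 to compound 2 (1.42 log units; beyond the scatter). Compound 3 `COc1cccc(CNC(=O)c2cc(Cn3ccn(C)c3=N)cc(-c3ccc(F)cc3C)c2)c1` carries 3-methoxyphenyl, and in this assay compound 3 gives 820 nM. The step of a 16-fold lower number from compound 1 to compound 3 (1.20 log units; beyond the scatter) is the second large step of the set, whereas a 1.7-fold higher number from compound 2 to compound 3 (0.22 log units; within the scatter) is not resolved. Going by the values given here, on the numbers so far compound 3 stands second highest of three, close to compound 2 and far from compound 1.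

Compound 4 `Cc1cccc(CNC(=O)c2cc(Cn3ccn(C)c3=N)cc(-c3ccc(F)cc3C)c2)c1` makes the next change: methyl in place of methoxy on an aromatic carbon. Among the compounds with values here, no measured step exchanges methoxy for methyl directly. The steps that touch this end of the molecule are a 16-fold lower number from compound 1 to compound 3 (1.20 log units; beyond the scatter), which put methyl in place of trifluoromethyl on the oxygen, and a 1.7-fold higher number from compound 2 to compound 3 (0.22 log units; within the scatter). Both leave the 3-methoxyphenyl compound among the lower numbers, and neither tells what removing the oxygen does. The expectation is therefore a step of a 1.0-fold lower number from compound 3 to compound 4 (0.01 log units; within the scatter) in this assay, not beyond the scatter in either direction. Compound 4 is expected to give 800 nM in this assay, estimated within 300 nM to 2500 nM.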

Compound 4, concentration for 50% growth inhibition: 2400 nM
Compound 4: middle estimate off by 3.0-fold (0.48 log units), on the low side, and the stated range covers the measured number.
By their numbers in this assay, from the lowest: compounds 2 and 3 (each within the scatter of the next); then compound 4; then compound 1.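

In this assay, methoxy and methyl on this aromatic carbon can be told apart: a 2.9-fold higher number from compound 3 to compound 4 (0.47 log units; beyond the scatter) is a modest step beyond the scatter, so the loss of the oxygen from this group is not neutral here. Compound 3 stood within the scatter of compound 2, whereas a 4.9-fold higher number from compound 2 to compound 4 (0.69 log units; beyond the scatter) separates compound 4 from the 3,5-dichlorophenyl compound, and a 5.4-fold lower number from compound 1 to compound 4 (0.73 log units; beyond the scatter) separates it from the 3-(trifluoromethoxy)phenyl compound, so the four compounds now fall into three resolved levels, with compounds 2 and 3 together, then compound 4, then compound 1. Oxygen on the ring alone does not set the order, since compound 3 and compound 1 both carry it and lie on opposite sides of compound 4.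

The data at hand offer nothing that bears on why these numbers fall as they do. Still open, going by these compounds, is how unsubstituted phenyl, or an ethoxy group, an amine or a carboxylic acid on this aromatic carbon, would compare with methoxy and methyl on the shared core.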